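Phenyl in place of hydrogen on compound 3

The compounds below may be only part of what the source reports. "The series", "measured", "known", "first", "only" and "open" are said of these compounds alone.

Compound 1 `CCCc1nn(C)c2c(NC3CC3)nc(/C=C/c3nc(C)c(C)nc3C)nc12` gives 706000 nM
Compound 2 `COc1cc(/C=C/c2nc(Cl)cc(NC(C)C)n2)cc(OC)c1OC` gives < 40000 nM
Compound 3 `CNc1nc(/C=C/c2ccccc2)nc2ccsc12` gives > 1000000 nM

All three readings come from a functional assay on L02 cells (Homo sapiens) for inhibition, read by Griess assay, with stated times of 1 h and 24 h (a lower number here means a stronger inhibitor, a higher number a weaker inhibitor), and only one of them is an actual number. Compound 3 stands at > 1000000 nM, which is a limit of the assay and not a number, so the starting point of this step has no exact value. Compound 2 gives < 40000 nM, which is also a limit.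

The next compound is compound 4 `CN(c1ccccc1)c1nc(/C=C/c2ccccc2)nc2ccsc12`, and the change is phenyl in place of hydrogen on a nitrogen on an aromatic ring. In words, phenyl takes the place of hydrogen on a nitrogen on an aromatic ring, so methylamino becomes methyl(phenyl)amino.

Within the data shown here, no pair of measured compounds here differs in one place only, so nothing shows directly what such a change does in this assay. Among the measured compounds shown here, the one real number, from compound 1 at 706000 nM, suggests that a reading within the range of the assay is possible for a compound of this kind. A moderate move towards a lower number, meaning a stronger inhibitor, is therefore expected, though it may not clear the scatter. The estimated step is an at least 2.5-fold lower number from compound 3 to compound 4 (0.39 log units; beyond the scatter) and it remains uncertain. For compound 4 the expected value is 400000 nM, with an estimated range from 40000 nM to 1500000 nM.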

Compound 4, half-maximal inhibitory concentration: > 1000000 nM
Compound 4: only a limit was reported; the forecaster's own chance of this, stated with the estimate: 35%; at least 2.5-fold (0.39 log units) between middle value and limit.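

Compound 3 and compound 4 both give only a limit of the assay and not a number, so the step from one to the other cannot be read. The compounds shown leave open whether phenyl in place of hydrogen on that nitrogen changes the reading in this assay at all, in either direction.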